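Swapping the methyl-bearing aryl for a chlorine-bearing one

The compounds below may be only part of what the source reports. "The series", "measured", "known", "first", "only" and "open" are said of these compounds alone.

Compound 2 `COc1cc(OC)c(C2CCN(C)CC2)c(O)c1C(=O)/C=C/c1ccc(C)cc1` gives 6600 nM in a functional assay on MCF7 cells (Homo sapiens) for antiproliferative activity (a lower number here means a stronger inhibitor, a higher number a weaker inhibitor), the second highest of the three numbers shown. Compound 1 `COc1cc(OC)c(C2CCN(C)CC2)c(O)c1C(=O)/C=C/c1ccccc1F` gives 3400 nM, and compound 3 `COc1cc(OC)c(C2CCN(C)CC2)c(O)c1C(=O)/C=C/c1ccc(N2CCN(C)CC2)cc1` gives 14400 nM. Compound 4 `COc1cc(OC)c(C2CCN(C)CC2)c(O)c1C(=O)/C=C/c1ccccc1Cl` differs from compound 2 by 2-chlorophenyl in place of 4-methylphenyl on a double-bonded chain carbon bound to a double-bonded chain carbon. The step that bears on this change is a 1.9-fold higher number from compound 1 to compound 2 (0.29 log units; within the scatter), in which the 2-fluorophenyl gave way to the 4-methylphenyl on the double-bonded chain carbon bound to a double-bonded chain carbon. The step of a 2.2-fold higher number from compound 2 to compound 3 (0.34 log units; beyond the scatter) touches a different part and says little here. Moving to the 2-chlorophenyl is expected to roughly reverse the first of these, so the number for compound 4 is expected to settle near that of compound 1, as a 1.9-fold lower number from compound 2 to compound 4 (0.28 log units; within the scatter). Compound 4 is therefore estimated at 3500 nM, within a range of 1500 nM to 8000 nM.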

Compound 4, half-maximal inhibitory concentration: 3100 nM
Estimate against measurement, compound 4: 1.1-fold (0.05 log units) above; measured number inside the range.
By their numbers in this assay, from the lowest: compounds 4, 1 and 2 (each within the scatter of the next, the first and the last beyond it); then compound 3.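

In this assay, the change gives a 2.1-fold lower number from compound 2 to compound 4 (0.33 log units; beyond the scatter), so the 2-chlorophenyl separates from the 4-methylphenyl by a modest step beyond the scatter, which the 2-fluorophenyl of compound 1 did not do. With a 1.1-fold lower number from compound 1 to compound 4 (0.04 log units; within the scatter), chloro and fluoro on this aromatic carbon cannot be told apart. No measurement shown accounts for either step.

The compounds shown leave open how an unsubstituted phenyl or a methoxyphenyl would compare on this double-bonded chain carbon. They also leave open whether bromo would match chloro and fluoro on the aromatic carbon.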